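A few compounds are considered here, and "the series" means these few. Any claim that something is new, unique, unknown or untested is made for them only; others in the source may bear on it.

Compound 1 `COc1ccc2nccc(C3CN(CC4CCN(Cc5cc6ccccc6[nH]5)CC4)C(=O)O3)c2c1` gives in an in vitro functional assay on RBL cells for antagonist activity at C-C chemokine receptor type 8 (Homo sapiens), read by FLIPR and calcium flux (a lower number here means a stronger inhibitor, a higher number a weaker inhibitor), only a limit, < 50200 nM.
Compound 2 `O=C1OC(c2ccncc2)CN1C1CCN(Cc2cc3ccccc3[nH]2)CC1` gives in this assay likewise only a limit, < 50200 nM.
Compound 3 `COc1ccc2nccc(C3CN(C4CCN(Cc5cc6ccccc6n5C)CC4)C(=O)O3)c2c1` gives in this assay 3160 nM.

For the measured compounds named here, compound 3 thus stands as the only real number in this set; the other two values are limits, as summarised in the limit of < 50200 nM in this assay, at which 2 of the 3 values shown sit. Compound 4 `CCCCCCN1CCC(N2CC(c3ccnc4ccc(OC)cc34)OC2=O)CC1` differs from compound 3 in a single place: pentyl in place of 1-methyl-1H-indol-2-yl on a saturated chain carbon bound to an amine nitrogen in a ring. Going by the values given here, no step between two measured compounds is available to anchor such a change, so the expectation rests on compound 3 alone. The account expects compound 4 to come out as a weaker inhibitor than compound 3, with a step of a 4.7-fold higher number from compound 3 to compound 4 (0.68 log units; beyond the scatter) that would lie beyond the usual scatter. Compound 4 is accordingly estimated at 15000 nM in this assay, within a range from 4000 nM to 50000 nM.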

Compound 4, half-maximal inhibitory concentration: 501 nM
Compound 4: the middle estimate sits 30-fold (1.48 log units) above what was measured, outside the stated range (below it).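

Pentyl in place of 1-methyl-1H-indol-2-yl gives a 6.3-fold lower number from compound 3 to compound 4 (0.80 log units; beyond the scatter) in this assay. For this pair, the place on a saturated chain carbon bound to an amine nitrogen in a ring therefore does not need the 1-methyl-1H-indol-2-yl group, and a chain with no ring gives the stronger inhibitor. Nothing shown gives a cause for this step.

Going by these compounds, how a longer chain, a branched chain or a chain ending in an amine would read at this place remains open. So does whether the same change would hold with the groups of compound 1 or compound 2.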